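A few compounds are considered here, and "the series" means these few. Any claim that something is new, unique, unknown or untested is made for them only; others in the source may bear on it.

Of the compounds shown here, three on the shared core have numbers so far in a functional assay on MDA-MB-231 cells (Homo sapiens) for antiproliferative activity, read by MTT assay, with a stated time of 72 h; a higher number here means a weaker inhibitor, a lower number a stronger inhibitor. Compound 1 `O=C(CCc1cccc2c1B(O)OC2)Nc1ccc(Br)cc1` gives 5300 nM. Compound 2 `CC(C)c1cccc(NC(=O)CCc2cccc3c2B(O)OC3)c1` gives 1600 nM, the lower of the two numeric values, and the gap up to compound 1 lies beyond the scatter. Compound 3 `COc1ccc(NC(=O)CCc2cccc3c2B(O)OC3)cc1OC` is recorded only as a limit, > 100000 nM.

Compound 4 `O=C(CCc1cccc2c1B(O)OC2)Nc1cccc(-c2ccc(F)cc2)c1` is still unmeasured. It departs from compound 2 in one place: 4-fluorophenyl in place of isopropyl on an aromatic carbon. In words, 4-fluorophenyl stands in place of isopropyl on an aromatic carbon, meta to a large group.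

Among the compounds with values here, no measured pair differs in one place only, so the expectation has little to rest on. The closest guide is the numeric range, with compound 2 at 1600 nM and compound 1 at 5300 nM. The limit on compound 3 leaves some risk of a much weaker result. In this assay, a small move toward a higher number is expected, one that may not clear the scatter. The expected change is a 1.6-fold higher number from compound 2 to compound 4 (0.19 log units; within the scatter). For compound 4 the estimated value is 2500 nM, with an expected range of 600 nM to 12000 nM.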

Compound 4, half-maximal inhibitory concentration: 250 nM
The estimate for compound 4 lay 10-fold (1.00 log units) above the measured number; the whole stated range lies above it.
By their numbers in this assay, from the lowest: compound 4; then compound 2; then compound 1. At a limit, above all of these: compound 3.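

In this assay, within the data shown here, the exchange of isopropyl for 4-fluorophenyl on an aromatic carbon, meta to a large group, gives a 6.4-fold lower number from compound 2 to compound 4 (0.81 log units; beyond the scatter) and is the first single-place step. The earlier compounds shown here could not show what this place accepts; it now carries a group of 7 heavy atoms with a six-membered aromatic ring instead of one of 3 heavy atoms with no ring, and the number falls rather than rises. The values shown give no cause for this step, and the one limit in the set has no bearing on it.

One exchange at one place cannot separate the part played by the added ring from that of the fluorine, so a plain phenyl group would be needed to tell them apart, and an amine or a carboxylic acid on the outer ring would test how far the group can be varied. Among these compounds, compound 3, with > 100000 nM recorded as a limit and not as a number, is joined to no other compound here by a single change, so it adds nothing about this place.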